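From pyridin-4-yl to carbamoyl on a saturated ring carbon

A few compounds are considered here, and "the series" means these few. Any claim that something is new, unique, unknown or untested is made for them only; others in the source may bear on it.

Among the measured compounds shown here, in a functional assay on Caco-2 cells (Homo sapiens) for inhibition, read by sulforhodamine B assay, with a stated time of 48 h (a lower number here means a stronger inhibitor, a higher number a weaker inhibitor), compound 3 (`O=c1c([C@@H]2C[C@H](c3ccncc3)ON2c2ccccc2)coc2ccccc12`) gives 37000 nM as the only true number in this small set. Compound 1 (`COC(=O)[C@H]1C[C@@H](c2coc3ccccc3c2=O)N(c2ccccc2)O1`) reads > 60000 nM and that value is a limit, not a number. Compound 2 (`O=c1c([C@@H]2C[C@H](c3ccccc3)ON2c2ccccc2)coc2ccccc12`) reads > 60000 nM and that too is a limit. Between these two lies a step that the two limits leave unreadable from compound 1 to compound 2 with nothing further to be read from it.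

Compound 4 (`NC(=O)[C@H]1C[C@@H](c2coc3ccccc3c2=O)N(c2ccccc2)O1`) carries carbamoyl in place of pyridin-4-yl on a saturated ring carbon.

For the measured compounds named here, two measured steps bear on this change, and both bring pyridin-4-yl in. One is an at least 1.6-fold lower number from compound 1 to compound 3 (0.20 log units; that floor lies within the scatter) as methoxycarbonyl leaves. The other is an at least 1.6-fold lower number from compound 2 to compound 3 (0.20 log units; that floor lies within the scatter) as phenyl leaves. Both are floors set by limits, and they lie within the scatter, so neither proves a real gain. Going by the values given here, compound 4 gives up the one group that has so far produced a number, so a small move towards higher numbers is expected, and a reading at the limit would be no surprise. The expected change is a 1.4-fold higher number from compound 3 to compound 4 (0.13 log units; within the scatter) and it is not expected to exceed the scatter. For compound 4 the estimate is 50000 nM with an expected range from 22000 nM to 110000 nM if this assay returns a number at all.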

Compound 4, half-maximal inhibitory concentration: > 60000 nM
Compound 4 ended at the assay's limit; the forecaster's own chance of this, stated with the estimate: 55%; middle value at least 1.2-fold (0.07 log units) away from the limit.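

In this assay, carbamoyl on this saturated ring carbon, which has no ring and fewer heavy atoms than pyridin-4-yl, joins methoxycarbonyl and phenyl at the same limit, leaving compound 3 as the only exception among the four compounds: the limit of > 60000 nM in this assay, at which 3 of the 4 values shown sit. The one new step that can be read is an at least 1.6-fold higher number from compound 3 to compound 4 (0.20 log units; that floor lies within the scatter), so pyridin-4-yl cannot yet be shown to differ from carbamoyl at this position. The steps from compound 1 and from compound 2 to compound 4 cannot be read, as both ends of each are limits, and so the change from methoxy to amino on the carbonyl carbon shows no readable effect here.

Going by these compounds, how far compound 1, compound 2 and compound 4 lie past the limit remains open, and with it whether any of the four groups truly differs from the others at this position. Also open, on these data alone, is how a carboxylic acid, an aminomethyl group or a pyridin-3-yl ring on this same ring carbon would read in this assay.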